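Brominated phenol series: cytotoxicity notes toward compound 3

This account rests on a few compounds, and the source may have more. Where it says the series, first, only, none or still open, it means among the compounds named here.

Compound 1 `COC(=O)C1=C(c2cc(Br)c(O)c(Br)c2)C(=O)[C@](c2ccc(O)c(Br)c2)(c2cc(Br)c(O)c(Br)c2)C1=O` — in a functional assay on K562 cells (Homo sapiens) for cytotoxicity, read by sulforhodamine B assay, with a stated time of 72 h (on this read-out higher numbers stand for weaker inhibition and lower numbers for stronger inhibition), a limit only, > 10000 nM
Compound 2 `COC(=O)C1=C(c2cc(Br)c(O)c(Br)c2)[C@](OC)(c2ccc(O)c(Br)c2)O[C@@]1(C(=O)OC)c1cc(Br)c(O)c(Br)c1` — in this assay a limit only, > 10000 nM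

Compound 2 stands at the edge of the measured range: in this assay compound 2 returns only the limit > 10000 nM, not a number. Compound 1 likewise gives only the limit > 10000 nM. For the measured compounds named here, the whole picture so far is the limit of > 10000 nM in this assay, at which 2 of the 2 values shown sit; with no measured step between the two, they show only that neither reaches a number within the tested range.

Compound 3 `COC(=O)C1=C(c2cc(Br)c(O)c(Br)c2)[C@](OC)(c2cc(Br)c(O)c(Br)c2)O[C@@]1(C(=O)OC)c1cc(Br)c(O)c(Br)c1` differs from compound 2 in one place: bromo in place of hydrogen on an aromatic carbon. Cut one bond further out, the change reads 3-bromo-4-hydroxyphenyl to 3,5-dibromo-4-hydroxyphenyl, on an aromatic carbon ortho to a hydroxy group and meta to a bromo group. Going by the values given here, no measured step tells the size of such a change, so no shift beyond the scatter is expected in either direction, and a repeat of the limit is the likeliest outcome. The step expected is a step that the limit leaves unreadable from compound 2 to compound 3. Compound 3 is estimated at 15000 nM, within 5000 nM to 50000 nM.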

Compound 3, half-maximal inhibitory concentration: > 10000 nM
Compound 3: only a limit was reported (the forecaster's own chance of this, stated with the estimate: 80%); the middle value lies beyond the limit too.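

In this assay compound 3 returns only the limit > 10000 nM and compound 2 also returns only a limit, so no step can be read between compound 2 and compound 3. The compounds shown leave open what bromo in place of hydrogen does to a measurable cytotoxicity value.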